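This account rests on a few compounds, and the source may have more. Where it says the series, first, only, none or still open, it means among the compounds named here.

Three compounds share a phenacyl-thio group on a triazole core and have been tested in a functional assay on the whole organism (strain albino) for inhibition, with Rattus norvegicus as the target, read by paw edema, with a stated time of 5 h, at a dose of 0.28 mmol/kg by the oral route; a lower number here means less inhibition, a higher number more inhibition at the dose given (going by the name of the read-out). Compound 1 `C=CCn1c(SCC(=O)c2ccccc2)nnc1-c1ccc(OC)c(OC)c1` gives 62%, compound 2 `C=CCn1c(SCC(=O)c2ccccc2)nnc1-c1ccc(OC)cc1` gives 61%, and compound 3 `O=C(CSc1nnc(-c2ccccc2)n1-c1ccccc1)c1ccccc1` gives 63%; these three numbers lie within the scatter of one another. For the measured compounds named here, the one counted change, (methoxy in place of hydrogen on an aromatic carbon), produced a number 1 percentage points higher from compound 2 to compound 1 (within the scatter). The difference between the cores of compound 2 and compound 3 is not broken down here. Compound 4 `COc1ccc(-c2nnc(SCC(=O)c3ccccc3)n2-c2ccccc2)cc1` has not yet been measured in this assay; it differs from compound 3 by methoxy in place of hydrogen on an aromatic carbon. This is the same kind of change as before, but here the place is para to a large group, whereas before it was ortho to a methoxy group and meta to a large group. Because a number 1 percentage points higher from compound 2 to compound 1 (within the scatter) was within the scatter, a step of similar size, a number 1 percentage points higher from compound 3 to compound 4 (within the scatter), is expected. Compound 4 is therefore estimated at 64%.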

Compound 4, a percentage reported as inhibition, in the whole organism at one dose (the size of the read-out at that dose, not a potency): 61%
Compound 4: middle estimate off by 3 percentage points, on the high side; the range from low to high includes it.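

In this assay, methoxy in place of hydrogen gave a number 2 percentage points lower from compound 3 to compound 4 (within the scatter), and the two readings of this change on different cores do not differ beyond the scatter: the same change on two cores in this assay, a number 1 percentage points higher (within the scatter) from compound 2 to compound 1 and a number 2 percentage points lower (within the scatter) from compound 3 to compound 4, 3 percentage points apart, within the scatter of two such steps

Neither step stands out from the scatter, so the series gives no sign that the core alters this change, but it also shows no effect of methoxy that could be carried from one core to another. Phenyl in place of allyl on the aromatic nitrogen likewise gave no change at the digits printed from compound 2 to compound 4 (within the scatter).

The compounds shown carry only hydrogen or methoxy groups on the aromatic ring at the core. From the compounds shown here alone, whether an amine or a carboxylic acid there, or a longer chain on the aromatic nitrogen, would move the paw edema inhibition beyond the scatter remains open.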